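The compounds below may be only part of what the source reports. "The series", "measured", "known", "first", "only" and "open" are said of these compounds alone.

Measured compounds:
In an ADME assay on microsomes from liver (Mus musculus) for metabolic stability, using NADPH, with a stated time of 10 min (on this read-out lower numbers stand for a less stable compound and higher numbers for a more stable compound), compound 1 `NCCCCN(C[C@H]1Cc2ncccc2CN1)[C@H]1CCCc2cccnc21` gives 86%.
In this assay compound 2 `CN(C)CCCCN(C[C@H]1Cc2ncccc2CN1)[C@H]1CCCc2cccnc21` gives 55%.
In this assay compound 3 `CN(CCCCN(C[C@H]1Cc2ncccc2CN1)[C@H]1CCCc2cccnc21)C1CCC(F)(F)CC1` gives 35%.

Compound 1 stands highest of the three numbers; compound 2 is nearest and compound 3 furthest. Compound 4 `CN(CCCCN(C[C@H]1Cc2ncccc2CN1)[C@H]1CCCc2cccnc21)C1CCOCC1` differs from compound 1 by methyl(oxan-4-yl)amino in place of amino on a saturated chain carbon, four bonds along the chain from an amine nitrogen. Both measured steps out of compound 1 bear on this change: a number 31 percentage points lower from compound 1 to compound 2 (beyond the scatter) and a number 51 percentage points lower from compound 1 to compound 3 (beyond the scatter), while a number 20 percentage points lower from compound 2 to compound 3 (beyond the scatter) separates those two. Compound 4, with its methyl(oxan-4-yl)amino group, is closer in structure to compound 3 than to compound 2, so a large downward step is expected, a number 46 percentage points lower from compound 1 to compound 4 (beyond the scatter). Compound 4 is therefore estimated to give 40% in this assay, within a range from 22% to 60%.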

Compound 4, percent of the compound remaining: 51%
The estimate for compound 4 lay 11 percentage points below the measured number; measured number inside the range.
By their numbers in this assay, from the lowest: compound 3; then compounds 4 and 2 (each within the scatter of the next); then compound 1.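

In this assay, the oxan-4-yl ring separates itself from the 4,4-difluorocyclohexyl ring on the same amine nitrogen, with a number 16 percentage points higher from compound 3 to compound 4 (beyond the scatter), yet it does not recover the number of the free amino group, with a number 35 percentage points lower from compound 1 to compound 4 (beyond the scatter). Oxan-4-yl in place of methyl on that nitrogen gives a number 4 percentage points lower from compound 2 to compound 4 (within the scatter), so here this ring and methyl cannot be told apart. Nothing available explains these differences. On these data alone, it remains open whether an oxan-4-ylamino group, without the methyl, or a morpholine would stand nearer to compound 1.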